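Adding one fluoro to compound 1: what to expect

This account rests on a few compounds, and the source may have more. Where it says the series, first, only, none or still open, it means among the compounds named here.

Values so far in an ADME assay on a cell-free system (plasma, Rattus norvegicus) for protein binding, using equilibrium dialysis; on this read-out higher numbers stand for a larger free fraction and lower numbers for a smaller free fraction
- compound 1 `O=S(=O)(c1ccc(O)c2ncccc12)C1CCCC1` gives 0.5
- compound 2 `O=S(=O)(c1ccc(C(F)(F)F)cc1)c1cc(F)c(O)c2ncccc12` gives 0.6
- compound 3 `O=S(=O)(c1ccc(F)cc1)c1cc(Cl)c(O)c2ncccc12` gives 0.5

Compound 1 stands level with compound 3 and within the scatter of compound 2, so nothing yet separates these three in this assay.

Compound 4 `O=S(=O)(c1cc(F)c(O)c2ncccc12)C1CCCC1` has not been measured. It keeps the core of compound 1 with one change (fluoro in place of hydrogen on an aromatic carbon): fluoro in place of hydrogen on an aromatic carbon, ortho to a hydroxy group. For the measured compounds named here, no two measured compounds differ in only one place, so this change has not been seen on its own. Compound 2 carries fluoro on that same carbon and gives 0.6 here, while compound 3 carries chloro there and gives 0.5 here. Both also differ from compound 1 elsewhere. With those values so close, no shift beyond the scatter is expected, and the estimated step is no change at the digits printed from compound 1 to compound 4 (within the scatter) in size. Compound 4 is estimated at 0.5, with an expected range from 0.3 to 0.7 as its likely span.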

Compound 4, unbound fraction: 0.2
The estimate for compound 4 lay 2.5-fold (0.40 log units) above the measured number, and the stated range ends above it.
By their numbers in this assay, from the lowest: compound 4; then compounds 1, 3 and 2 (each within the scatter of the next).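

In this assay, fluoro in place of hydrogen on an aromatic carbon, ortho to a hydroxy group, gives a 2.5-fold lower number from compound 1 to compound 4 (0.40 log units; beyond the scatter), which means a smaller free fraction. For the compounds shown here, this is the first view of the change on its own: compounds 2 and 3 also carry a halogen on this carbon, but each differs from compound 1 elsewhere as well, so neither could show what this one atom does. No measurement shown here gives a reason for the step.

Going by these compounds, it remains open whether a methoxy group or an amine on this same carbon would shift the free fraction in the same way, or whether chloro would do so on the core of compound 1. Whether fluoro has the same effect when the rest of the molecule differs also cannot be read from a single pair.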